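The compounds below may be only part of what the source reports. "The series", "measured", "known", "first", "only" and "open" are said of these compounds alone.

Of the compounds shown here, three with a shared core have been measured in an assay on HEK293 cells for displacement of a labelled ligand from Melanocortin receptor 4 (Homo sapiens); on this read-out lower numbers stand for stronger inhibition and higher numbers for weaker inhibition. Compound 1 `CCC(C)CN[C@H](c1cc(C(F)(F)F)ccc1N1CCN(C(=O)CCc2ccc(Cl)cc2Cl)CC1)C(C)CC` gives 2800 nM. Compound 2 `CCC(C)[C@H](NCCN)c1cc(C(F)(F)F)ccc1N1CCN(C(=O)CCc2ccc(Cl)cc2Cl)CC1` gives 56 nM, and compound 3 `CCC(C)[C@H](NC(=O)CN)c1cc(C(F)(F)F)ccc1N1CCN(C(=O)CCc2ccc(Cl)cc2Cl)CC1` gives 18 nM. Compound 3 thus has the lowest number of the three: the step of a 3.1-fold lower number from compound 2 to compound 3 (0.49 log units; beyond the scatter) is modest, while a 160-fold lower number from compound 1 to compound 3 (2.19 log units; beyond the scatter) is large, as is a 50-fold lower number from compound 1 to compound 2 (1.70 log units; beyond the scatter).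

Compound 4 `CCN[C@@H](CC(C)C)c1cc(C(F)(F)F)ccc1N1CCN(C(=O)CCc2ccc(Cl)cc2Cl)CC1` differs from compound 3 in one place: 1-(ethylamino)-3-methylbutyl in place of 1-(((aminomethyl)carbonyl)amino)-2-methylbutyl on an aromatic carbon. The change removes the terminal amine and the carbonyl that compound 3 carries and puts a plain ethyl on the nitrogen, which recalls compound 1, where an alkyl group on the nitrogen and no terminal amine went with the highest number in this assay. Among the compounds with values here, the ethyl is smaller than the 2-methylbutyl of compound 1, and the side chain also shifts from 2-methylbutyl to 3-methylbutyl, for which no measured step exists. The expectation is therefore a large rise in this assay, a 44-fold higher number from compound 3 to compound 4 (1.65 log units; beyond the scatter), though probably short of the full gap back up to the highest measured number, because a 160-fold lower number from compound 1 to compound 3 (2.19 log units; beyond the scatter) also covers the bigger alkyl. Compound 4 is estimated at 800 nM, with a likely range from 150 nM to 4000 nM.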

Compound 4, inhibition constant: 170 nM
Compound 4: middle estimate off by 4.7-fold (0.67 log units), on the high side, and the stated range covers the measured number.
By their numbers in this assay, from the lowest: compound 3; then compound 2; then compound 4; then compound 1.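

In this assay, the 1-(ethylamino)-3-methylbutyl group gives a 16-fold lower number from compound 1 to compound 4 (1.22 log units; beyond the scatter), so a simple alkyl on the nitrogen at this aromatic carbon does not by itself bring the highest number seen with compound 1. Groups with a terminal amine still give lower numbers, as shown by a 9.4-fold higher number from compound 3 to compound 4 (0.98 log units; beyond the scatter) and a 3.0-fold higher number from compound 2 to compound 4 (0.48 log units; beyond the scatter), yet compound 4 reaches its value with neither a terminal amine nor a carbonyl. No measurement here points to a cause for these steps.

Going by these compounds, compound 4 changes both the group on the nitrogen and the branched side chain, so the share of each in these steps stays unknown. On these data alone, it also remains open how a methyl or propyl on the nitrogen, or a longer 3-aminopropyl chain, would compare.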